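Oxolanyl ether in place of methoxy on compound 2

The source may report more compounds than this note shows. Statements on the series, on what has been measured and on what is new or still open speak of the compounds shown alone.

Going by the values given here, compound 2 `COc1cc2ncnc(N3CCc4ccccc43)c2cc1NC(=O)/C=C/CN1CCCC1` carries the lowest number of the two measured so far. In a functional assay on PC-3 cells (Homo sapiens) for antiproliferative activity, read by MTT assay, with a stated time of 72 h (a higher number here means a weaker inhibitor, a lower number a stronger inhibitor), compound 2 gives 2620 nM. Compound 1 `CC(C)/C=C/C(=O)Nc1cc2c(N3CCc4ccccc43)ncnc2cc1O[C@@H]1CCOC1`, which differs from it in more than one place, gives in this assay 11200 nM, a higher number beyond the scatter. Compound 3 `O=C(/C=C/CN1CCCC1)Nc1cc2c(N3CCc4ccccc43)ncnc2cc1O[C@@H]1CCOC1` is not yet measured; it differs from compound 2 by oxolan-3-yl in place of methyl on an oxygen on an aromatic ring. Among the compounds with values here, no measured pair isolates this single change, so the step is expected to be small, within the scatter or a slight weakening, as a 1.3-fold higher number from compound 2 to compound 3 (0.13 log units; within the scatter). Compound 3 is accordingly estimated at 3500 nM, within a range from 1200 nM to 10000 nM.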

Compound 3, half-maximal inhibitory concentration: 1510 nM
For compound 3 the middle estimate is 2.3-fold (0.37 log units) above the measured one; measured number inside the range.
By their numbers in this assay, from the lowest: compounds 3 and 2 (each within the scatter of the next); then compound 1.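

In this assay the oxygen on the aromatic ring accepts oxolan-3-yl in place of methyl, with a 1.7-fold lower number from compound 2 to compound 3 (0.24 log units; within the scatter) as the step, so the two ethers cannot be told apart. Going by these compounds alone, with the oxolanyl ether held constant, (pyrrolidin-1-yl)methyl in place of isopropyl gives a 7.4-fold lower number from compound 1 to compound 3 (0.87 log units; beyond the scatter) as the first single-place step beyond the scatter. Nothing at hand bears on the reason for either step.

Open, as far as these compounds go, is whether a longer chain ending in an amine on that oxygen would shift the number beyond the scatter. Also open, from the compounds shown here alone, is how a piperidin-1-yl or dimethylamino group would compare with the pyrrolidin-1-yl.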